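From methoxy to trifluoromethyl on compound 1

This account rests on a few compounds, and the source may have more. Where it says the series, first, only, none or still open, it means among the compounds named here.

Among the compounds with values here, in a functional assay on A549 cells (Homo sapiens) for cytotoxicity, read by MTT assay, with a stated time of 72 h (on this read-out lower numbers stand for stronger inhibition and higher numbers for weaker inhibition), compound 1 (`COc1ccc(Nc2nc3ccccc3nc2S(=O)(=O)c2ccccc2)cc1`) gives 11900 nM, the highest of the three numbers measured so far. Compound 2 (`COc1cc(Nc2nc3ccccc3nc2S(=O)(=O)c2ccccc2)cc(OC)c1`) gives 70 nM, and compound 3 (`Nc1cccc(Nc2nc3ccccc3nc2S(=O)(=O)c2ccccc2)c1`) gives 1590 nM.

Compound 4 (`O=S(=O)(c1ccccc1)c1nc2ccccc2nc1Nc1ccc(C(F)(F)F)cc1`) has not yet been measured. It differs from compound 1 by carrying trifluoromethyl in place of methoxy on an aromatic carbon, para to a large group: trifluoromethyl in place of methoxy on an aromatic carbon.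

Within the data shown here, two measured steps bear on this change, as both replace the 4-methoxyphenyl group of compound 1. With 3,5-dimethoxyphenyl, the large step is a 170-fold lower number from compound 1 to compound 2 (2.23 log units; beyond the scatter). With 3-aminophenyl, the modest step is a 7.5-fold lower number from compound 1 to compound 3 (0.87 log units; beyond the scatter). Among the measured compounds shown here, both point downward, but no measured compound carries trifluoromethyl, so they offer only a loose guide to direction and size.

A modest step is therefore expected, an estimated 4.0-fold lower number from compound 1 to compound 4 (0.60 log units; beyond the scatter). Compound 4 is expected to give about 3000 nM, with an estimated range of 500 nM to 15000 nM.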

Compound 4, half-maximal inhibitory concentration: > 50000 nM
Compound 4: no number, only a limit (the forecaster's own chance of this, stated with the estimate: 10%); at least 16-fold (1.22 log units) between middle value and limit.
By their numbers in this assay, from the lowest: compound 2; then compound 3; then compound 1. At a limit, above all of these: compound 4.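

In this assay compound 4 gives no number, only a limit of the assay: the limit of > 50000 nM in this assay, at which 1 of the 4 values shown sits. At this position, trifluoromethyl in place of methoxy gives an at least 4.2-fold higher number from compound 1 to compound 4 (0.62 log units; beyond the scatter) and so moves the number upward, whereas both earlier replacements of the 4-methoxyphenyl group moved it downward. The gaps to the two better compounds are wider still, with an at least 31-fold higher number from compound 3 to compound 4 (1.49 log units; beyond the scatter) and an at least 710-fold higher number from compound 2 to compound 4 (2.85 log units; beyond the scatter) on the same read-out, which shows that a change at this one aromatic carbon can weaken compound 1 rather than improve it.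

The compounds shown leave open whether other groups on this aromatic carbon, such as an amine, a hydroxyl or a single chlorine atom, would also raise the number. Also open, on these data alone, is whether trifluoromethyl elsewhere on this ring would read the same way.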